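A few compounds are considered here, and "the series" means these few. Any claim that something is new, unique, unknown or untested is made for them only; others in the source may bear on it.

Three compounds share one core, and all three meet the same fate in a functional assay on SMMC-7721 cells (Homo sapiens) for antiproliferative activity, read by MTT assay, with a stated time of 48 h; on this read-out higher numbers stand for weaker inhibition and lower numbers for stronger inhibition. Compound 1 `Cn1cc(C2=C(c3nn(CCn4ccnc4)c4ncccc34)C(=O)NC2=O)c2ccccc21` gives a value that is a limit of the assay, > 100000 nM, not a number. Compound 2 `Cn1cc(C2=C(c3nn(CCCO)c4ncccc34)C(=O)NC2=O)c2ccccc21` likewise gives only a limit, > 100000 nM. Between them lies the step that the two limits leave unreadable from compound 1 to compound 2, which the two limits leave without a readable size. Compound 3 `Cn1cc(C2=C(c3nn(CCCn4cncn4)c4ncccc34)C(=O)N(c3ccccc3)C2=O)c2ccccc21` also stands at a limit, > 100000 nM, so no number has been seen for it either; in fact (the limit of > 100000 nM in this assay, at which 3 of the 3 values shown sit).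

Compound 4 `Cn1cc(C2=C(c3nn(CCCn4cncn4)c4ncccc34)C(=O)NC2=O)c2ccccc21` differs from compound 3 in one place: hydrogen in place of phenyl on an amide-type nitrogen in a ring. Among the measured compounds shown here, no measured step bears on this exchange, and none of the three measured values gives a number to move from. The expectation for compound 4 in this assay is therefore guided only by the fact that every neighbour sits at the limit, so the step of a number no higher from compound 3 to compound 4 (the limit leaves the size open) is estimated to stay within the scatter. Compound 4 is expected to give about 100000 nM, between 30000 nM and 300000 nM, most likely reported again as a limit.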

Compound 4, half-maximal inhibitory concentration: > 100000 nM
Compound 4: only a limit was reported; the forecaster's own chance of this, stated with the estimate: 75%; the middle value sits exactly at the limit.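

The steps from compound 4 to compound 1, compound 2 and compound 3 cannot be read, as each compound gives only a limit in this assay: the limit of > 100000 nM in this assay, at which 4 of the 4 values shown sit. The compounds shown leave open whether any of the exchanged groups changes the inhibition, and by how much.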